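The compounds below may be only part of what the source reports. "The series", "measured", "known", "first", "only" and "open" are said of these compounds alone.

Compound 1 `Cc1nc(Cc2ccccc2)n2c(O)nncc12`: > 48000 nM in a functional assay for inhibition, with Homo sapiens as the target; a lower number here means a stronger inhibitor, a higher number a weaker inhibitor
Compound 2 `CCc1nc(C)c2cnnc(O)n12`: > 48000 nM
Compound 3 `Cc1nc(C)n2c(O)nncc12`: > 48000 nM

In this assay compound 1 gives > 48000 nM, which is a limit of the assay and not a number. Compound 2 likewise gives only a limit, > 48000 nM. Compound 3 also gives only a limit, > 48000 nM. Compound 1 therefore stands at the limit of > 48000 nM in this assay, at which 3 of the 3 values shown sit, with no number that would place it against its two neighbours. The three measured steps all change the group on a saturated chain carbon bound to an aromatic carbon: a step that the two limits leave unreadable from compound 1 to compound 2, a step that the two limits leave unreadable from compound 1 to compound 3 and a step that the two limits leave unreadable from compound 2 to compound 3. None of them can be read, and none of them touches the place that changes next.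

Compound 4 `Oc1nncc2cnc(Cc3ccccc3)n12` differs from compound 1 in one respect: hydrogen in place of methyl on an aromatic carbon. Within the data shown here, no measured step bears on this change, and the measured compounds supply no number from which a direction or size could be read. The expectation for compound 4 is that it, too, comes out only as a limit, estimated at 60000 nM with a range from 20000 nM to 200000 nM. The step this estimate means, a step that the limit leaves unreadable from compound 1 to compound 4, is expected to stay within the scatter, with no direction to it.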

Compound 4, half-maximal inhibitory concentration: > 48000 nM
Compound 4: no number, only a limit; the forecaster's own chance of this, stated with the estimate: 85%; the middle value lies beyond the limit too.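

Compound 4, like compound 1, gives only a limit in this assay and not a number, so the step between them cannot be read: the limit of > 48000 nM in this assay, at which 4 of the 4 values shown sit.

The compounds shown leave open whether any of these changes to the shared core affects inhibition at all, and none of the four gives a number to compare.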